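The source may hold more compounds than are shown below. What is called first, only, known or untested is meant among the compounds shown, and "the series" means these compounds.

Measured in a functional assay on MCF7 cells (Homo sapiens) for inhibition, read by colorimetric assay and MTT assay, with a stated time of 72 h; on this read-out higher numbers stand for weaker inhibition and lower numbers for stronger inhibition
- compound 1 `C=CCCCCOc1ccccc1-c1cnc(OCCC=C)n1C` gives 8000 nM
- compound 2 `C=CCCCCOc1ccc(OC)cc1-c1cnc(OCCC=C)n1C` gives 37000 nM
- compound 3 `C=CCCCCOc1ccc(F)cc1-c1cnc(OCCC=C)n1C` gives 43000 nM

Compound 1 holds the lowest number of the three in this assay, and its steps to both others lie beyond the scatter. The open question is compound 4 `C=CCCCCOc1ccccc1-c1cnc(OCCCC=C)n1C`, which differs from compound 1 as follows: allyl in place of vinyl on a saturated chain carbon, two bonds along the chain from an oxygen on an aromatic ring. Put another way, (but-3-en-1-yl)oxy becomes (pent-4-en-1-yl)oxy.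

Among the compounds with values here, no measured step changes this chain. The steps available are substitutions on an aromatic carbon: a 4.6-fold higher number from compound 1 to compound 2 (0.67 log units; beyond the scatter) with methoxy, and a 5.4-fold higher number from compound 1 to compound 3 (0.73 log units; beyond the scatter) with fluoro. Those two end points do not separate, with a 1.2-fold higher number from compound 2 to compound 3 (0.07 log units; within the scatter). These steps show that a single change can move the number modestly in this series, but they give no direction for a change in the chain. A step beyond the scatter is therefore not expected, although the uncertainty runs both ways.

The estimated change is a 1.1-fold higher number from compound 1 to compound 4 (0.05 log units; within the scatter), and it is expected to stay within the scatter. For compound 4 the estimated value is 9000 nM, with an expected range from 3500 nM to 25000 nM.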

Compound 4, half-maximal inhibitory concentration: 7000 nM
Estimate against measurement, compound 4: 1.3-fold (0.11 log units) above; low and high end bracket the measured number.
By their numbers in this assay, from the lowest: compounds 4 and 1 (each within the scatter of the next); then compounds 2 and 3 (each within the scatter of the next).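

In this assay, the change from (but-3-en-1-yl)oxy to (pent-4-en-1-yl)oxy gives a 1.1-fold lower number from compound 1 to compound 4 (0.06 log units; within the scatter), so this pair provides a direct reading on the chain, and the two chain lengths cannot be told apart in this assay. The contrast lies with the substitutions on the aromatic carbon, where methoxy gives a 4.6-fold higher number from compound 1 to compound 2 (0.67 log units; beyond the scatter) and fluoro gives a 5.4-fold higher number from compound 1 to compound 3 (0.73 log units; beyond the scatter); allyl in place of vinyl at this chain position produces no step beyond the scatter, although a single pair sets no trend for the chain. No supporting measurement bears on this result.

Still open, going by these compounds, is whether a longer chain than pent-4-en-1-yl, a saturated chain in place of the terminal double bond, or an amine or a carboxylic acid at the chain end would also leave the number within the scatter of compound 1. Also open, on these data alone, is whether the (pent-4-en-1-yl)oxy chain behaves in the same way when combined with the methoxy of compound 2 or the fluoro of compound 3.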